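Removing the (2-methoxyethyl)amino group from compound 2

This account rests on a few compounds, and the source may have more. Where it says the series, first, only, none or still open, it means among the compounds named here.

Measured compounds:
compound 1 `COCCNc1nc(C)cc2c1c(N)nn2C`: -3%
compound 2 `COCCNc1nc(-c2ccccc2)cc2c1c(N)nn2C`: -1%

In an assay on isolated protein for inhibition of RAC-beta serine/threonine-protein kinase (Homo sapiens), read by mobility shift assay, tested at 30 uM (a lower number here means less inhibition, a higher number more inhibition at the concentration tested (going by the name of the read-out)), compound 2 gives -1%, a number within the scatter of compound 1, so neither compound shows inhibition that can be told apart from zero. Among the measured compounds shown here, the only measured step, a number 2 percentage points higher from compound 1 to compound 2 (within the scatter), concerns a phenyl in place of methyl on an aromatic carbon and left the read-out essentially unchanged. Compound 3 `Cn1nc(N)c2cnc(-c3ccccc3)cc21` differs from compound 2 by hydrogen in place of (2-methoxyethyl)amino on an aromatic carbon. No measured step touches this position, so the one step shown bears on it only in that both measured compounds sit at a flat baseline. Without a reason in the data for a change, the step from compound 2 to compound 3 is expected to be a number 1 percentage points higher from compound 2 to compound 3 (within the scatter), nothing beyond the scatter. Compound 3 is therefore estimated at 0%, in a range from -10% to 10%.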

Compound 3, a percentage reported as inhibition, at one concentration (the size of the read-out at that concentration, not a potency): 6%
Beside the measured number, compound 3's estimate is 6 percentage points below it; low and high end bracket the measured number.
By their numbers in this assay, from the lowest: compounds 1, 2 and 3 (each within the scatter of the next).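

Putting hydrogen in place of (2-methoxyethyl)amino on this aromatic carbon, next to the ring nitrogen, gives a number 7 percentage points higher from compound 2 to compound 3 (within the scatter) in this assay. Among the compounds shown here, this first measured step at the position shows that the whole side chain, with its 5 heavy atoms, can go without the read-out leaving the scatter, so the group is not needed to hold the flat baseline seen for the earlier compounds. No other data bear on this result, and nothing explains the small number printed for the step.

The compounds shown leave open whether a carboxylic acid, a morpholine or a longer alkyl chain on this carbon would move the read-out beyond the scatter. They also leave open whether any such group would behave differently with methyl in place of phenyl on the shared core.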